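The source may report more compounds than this note shows. Statements on the series, on what has been measured and on what is new or still open speak of the compounds shown alone.

The measured compounds:

Compound 1 `O=c1oc(Nc2ccccc2I)nc2cc(Cl)ccc12` gives 700 nM in an assay on isolated protein for inhibition of complement C1r subcomponent (Homo sapiens); on this read-out lower numbers stand for stronger inhibition and higher numbers for weaker inhibition.
Compound 2 `O=c1oc(Nc2ccccc2I)nc2cc(Cl)cc(Cl)c12` is reported only as a limit of this assay, > 62500 nM.
Compound 3 `Cc1ccc2c(=O)oc(Nc3ccccc3I)nc2c1` gives 800 nM in this assay.

Compound 3 holds the highest of the two numbers shown, but its nearest neighbour, compound 1, lies within the scatter, so the two are not separable: a 1.1-fold higher number from compound 1 to compound 3 (0.06 log units; within the scatter). Compound 2 sits at a limit, (the limit of > 62500 nM in this assay, at which 1 of the 3 values shown sits), reached by the step of an at least 89-fold higher number from compound 1 to compound 2 (1.95 log units; beyond the scatter), a change at a different position from the one followed here.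

Compound 4 `CC(C)c1ccc2c(=O)oc(Nc3ccccc3I)nc2c1` differs from compound 3 by isopropyl in place of methyl on an aromatic carbon. Within the data shown here, no measured step changes this group beyond the swap of chloro for methyl, which was within the scatter from compound 1 to compound 3. That exchange bears on the new step only loosely, since isopropyl is a larger group than either. The expectation is therefore a small step upward in this assay, a 1.9-fold higher number from compound 3 to compound 4 (0.27 log units; within the scatter), with wide uncertainty. For compound 4 the estimate is 1500 nM, with a range from 350 nM to 8000 nM.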

Compound 4, half-maximal inhibitory concentration: > 62500 nM
Compound 4 ended at the assay's limit; the forecaster's own chance of this, stated with the estimate: 8%; middle value at least 41-fold (1.61 log units) away from the limit.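

Replacing methyl with isopropyl on this aromatic carbon gives an at least 78-fold higher number from compound 3 to compound 4 (1.89 log units; beyond the scatter) in this assay, and replacing chloro with isopropyl gives an at least 89-fold higher number from compound 1 to compound 4 (1.95 log units; beyond the scatter). The earlier compounds shown here showed only that chloro and methyl could not be separated here; compound 4 shows that this equivalence does not extend to every carbon substituent, with isopropyl bringing 3 heavy atoms in place of 1 for methyl. Compound 4 is reported only as a limit of the assay: the limit of > 62500 nM in this assay, at which 2 of the 4 values shown sit.

The compounds shown leave open whether ethyl, which stands between methyl and isopropyl, would stay close to compound 3 or would already reach the limit. They also leave open whether a methoxy group or an amine at this position would behave like methyl or like isopropyl.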